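A few compounds are considered here, and "the series" means these few. Any claim that something is new, unique, unknown or untested is made for them only; others in the source may bear on it.

Compound 1 `ClCc1ccccc1Cn1cnc2nc(Cl)nc(Cl)c21` was examined in a functional assay on HCC 2998 cells (Homo sapiens) for cytotoxicity, read by sulforhodamine B assay, with a stated time of 48 h (a lower number here means a stronger inhibitor of growth, a higher number a weaker inhibitor of growth), where compound 1 gives 18600 nM. Its companion, compound 2 `ClCc1ccc(Cn2cnc3c(Cl)nc(Cl)nc32)cc1`, gives 10200 nM in this assay; the two numbers sit within the usual scatter of each other, so compound 1 stands at one end of the pair shown but is not set apart from compound 2 by more than repeated measurement would allow.

Compound 3 `ClCc1ccccc1Cn1cnc2ncnc(Cl)c21` has not been measured in this assay. It differs from compound 1 in one place (hydrogen in place of chloro on an aromatic carbon). For the measured compounds named here, no measured pair in this set shares this change, so nothing here fixes its size or direction. The expectation for compound 3 is a modest step from compound 1 toward a higher number, a 1.4-fold higher number from compound 1 to compound 3 (0.15 log units; within the scatter), though a step hidden inside the scatter would not surprise. On that basis compound 3 is estimated at 26000 nM, within a range of 8000 nM to 80000 nM.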

Compound 3, concentration for 50% growth inhibition: 2230 nM
For compound 3 the middle estimate is 12-fold (1.07 log units) above the measured one; measured number outside the range, below it.
By their numbers in this assay, from the lowest: compound 3; then compounds 2 and 1 (each within the scatter of the next).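

Putting hydrogen in place of chloro on the aromatic carbon between two ring nitrogen atoms gives, in this assay, an 8.3-fold lower number from compound 1 to compound 3 (0.92 log units; beyond the scatter). For the compounds shown here, this is the first step in the set that can be read at a single position, and it shows that the chloro group at this place is not required for growth inhibition: in this pair, the compound that lacks it is the stronger inhibitor of growth. No measured evidence on why this change has this effect is available here.

On these data alone, it remains open whether another group on this carbon, such as an amine or a methoxy group, would keep the lower number or lose it. Also open, as far as these compounds go, is whether the same change would give a step of similar size and direction in compound 2.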